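The source may hold more compounds than are shown below. What is called first, only, known or untested is meant among the compounds shown, and "the series" means these compounds.

Measured so far:
compound 1, `CCc1ccc2[nH]c(=O)c(CN(Cc3ccc(F)cc3)Cc3ccc4ccccc4c3)cc2c1`: > 5000 nM
compound 2, `Cc1ccc2[nH]c(=O)c(CN(Cc3ccc(OC(C)C)cc3)Cc3ccc(C(C)(C)C)cc3)cc2c1`: > 5000 nM

Both readings come from a toxicity assay on MDCK cells (Canis lupus familiaris) for cytotoxicity, read by crystal violet staining, with a stated time of 48 h; a lower number here means that less compound is tolerated, a higher number that more compound is tolerated. For compound 1 the value > 5000 nM is a limit of the assay, not a number. For compound 2 the value > 5000 nM is likewise a limit. Going by the values given here, compound 2 therefore stands at the limit, and the only other value shown, that of compound 1, sits at the same limit (the limit of > 5000 nM in this assay, at which 2 of the 2 values shown sit). Compound 3, `COc1ccc(C(C)N(Cc2ccc(C(C)(C)C)cc2)Cc2cc3cc(C)ccc3[nH]c2=O)cc1Cl`, has not yet been measured in this assay. It differs from compound 2 in a single place: 1-(3-chloro-4-methoxyphenyl)ethyl in place of 4-isopropoxybenzyl on an amine nitrogen. Among the compounds with values here, no step between measured compounds exists to calibrate such a change, so no direction can be drawn from the data. The step from compound 2 to compound 3 is expected to stay within the scatter, a step that the limit leaves unreadable from compound 2 to compound 3. Compound 3 is expected to give about 8000 nM, between 4000 nM and 20000 nM, most likely again reported only as a limit.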

Compound 3, half-maximal cytotoxic concentration: > 10000 nM
Compound 3: a limit, no number (the forecaster's own chance of this, stated with the estimate: 75%); middle value at least 1.2-fold (0.09 log units) away from the limit.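

Going by these compounds alone, compound 2 and compound 3 are both reported only as limits, not numbers, so no step between them can be read. The compounds shown leave open at what concentration any of them harms the cells, and whether 1-(3-chloro-4-methoxyphenyl)ethyl in place of 4-isopropoxybenzyl changes that.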